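Dichlorophenyl for aminophenyl on the shared core

The source may hold more compounds than are shown below. What is called first, only, known or untested is meant among the compounds shown, and "the series" means these compounds.

Of the compounds shown here, two have been measured in a functional assay on BT-549 cells (Homo sapiens) for inhibition, read by sulforhodamine B assay, with a stated time of 48 h; a lower number here means that less compound is tolerated, a higher number that more compound is tolerated. Compound 1 `COc1cc(-c2cc(/C=C/C(=O)c3ccc(N)cc3)[nH]n2)cc(OC)c1OC` gives 5760 nM in this assay, and compound 2 `COc1ccc(-c2cc(/C=C/C(=O)c3ccc(OC)c(OC)c3)[nH]n2)cc1` gives 7400 nM; the two values sit within the scatter of each other, so compound 1 holds no distinct place among the measured numbers. Compound 3 `COc1cc(-c2cc(/C=C/C(=O)c3ccc(Cl)c(Cl)c3)[nH]n2)cc(OC)c1OC` has not yet been measured. It differs from compound 1 as follows: 3,4-dichlorophenyl in place of 4-aminophenyl on a carbonyl carbon. Within the data shown here, no measured pair shows this change, so the expected step is a small one, in either direction or none beyond the scatter, and the estimate for compound 3 is 4500 nM, between 1300 nM and 15000 nM, meaning an expected step of a 1.3-fold lower number from compound 1 to compound 3 (0.11 log units; within the scatter).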

Compound 3, concentration lethal to 50% of the cells: 92600 nM
For compound 3 the middle estimate is 21-fold (1.31 log units) below the measured one, and the stated range ends below it.
By their numbers in this assay, from the lowest: compounds 1 and 2 (each within the scatter of the next); then compound 3.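

At the carbonyl carbon, the choice of aryl group matters in this assay: 3,4-dichlorophenyl in place of 4-aminophenyl gives a 16-fold higher number from compound 1 to compound 3 (1.21 log units; beyond the scatter), so more compound is tolerated on the shared core. Among these compounds, this is the first step at this position, and it lies beyond the scatter. Nothing measured on these compounds accounts for it.

Going by these compounds, the change removes the amine and adds both chlorines at once, so their separate shares remain open. Unsubstituted phenyl at this carbonyl carbon would be the missing reference point.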